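The source may hold more compounds than are shown below. What is called first, only, known or untested is meant among the compounds shown, and "the series" means these compounds.

Three compounds share one core and differ only in the group carried on the double-bonded chain carbon. In a functional assay on MGC-803 cells (Homo sapiens) for cytotoxicity, read by MTT assay, with a stated time of 72 h (a higher number here means a weaker inhibitor, a lower number a stronger inhibitor), compound 1 `CN(C)c1ccc(C=C2C(=O)N(c3ccc(Cl)cc3)N(c3ccc(Cl)cc3)C2=O)cc1` gives 80200 nM, compound 2 `O=C1C(=Cc2ccc(Br)cc2)C(=O)N(c2ccc(Cl)cc2)N1c1ccc(Cl)cc1` gives 16900 nM, and compound 3 `COc1cccc(C=C2C(=O)N(c3ccc(Cl)cc3)N(c3ccc(Cl)cc3)C2=O)c1` gives 26600 nM. Compound 2 has the lowest number of the three; the step of a 1.6-fold higher number from compound 2 to compound 3 (0.20 log units; within the scatter) lies within the scatter, while a 4.7-fold lower number from compound 1 to compound 2 (0.68 log units; beyond the scatter) lies beyond it. Compound 4 `O=C1C(=Cc2c[nH]c3ccccc23)C(=O)N(c2ccc(Cl)cc2)N1c1ccc(Cl)cc1` changes the same position: 1H-indol-3-yl in place of 4-bromophenyl on a double-bonded chain carbon bound to a double-bonded ring carbon. Within the data shown here, the measured swaps at this position are the only guide; one was modest and one stayed within the scatter, so a change here has not moved the number far. A step of a 1.2-fold lower number from compound 2 to compound 4 (0.08 log units; within the scatter) is therefore expected, not beyond the scatter. Compound 4 is estimated at 14000 nM, in the range 5000 nM to 40000 nM.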

Compound 4, half-maximal inhibitory concentration: 21800 nM
The estimate for compound 4 lay 1.6-fold (0.19 log units) below the measured number; measured number inside the range.
By their numbers in this assay, from the lowest: compounds 2, 4 and 3 (each within the scatter of the next); then compound 1.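

Here the 1H-indol-3-yl group brings a second aromatic ring and a hydrogen-bond donor, yet the result is a 1.3-fold higher number from compound 2 to compound 4 (0.11 log units; within the scatter) and a 1.2-fold lower number from compound 3 to compound 4 (0.09 log units; within the scatter) with no separation from either single-ring group. The 4-(dimethylamino)phenyl group alone stays apart, with a 3.7-fold lower number from compound 1 to compound 4 (0.57 log units; beyond the scatter) as the step away from it. Nothing measured here explains this pattern. Still open, from the compounds shown here alone, is whether an amine or a carboxylic acid on this chain carbon would shift the number beyond the scatter.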